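This account rests on a few compounds, and the source may have more. Where it says the series, first, only, none or still open, it means among the compounds named here.

Measured compounds:
- compound 1, `O=C(O)CCCCCCOc1ccc2c(=O)c(-c3ccc(O)cc3)coc2c1`, 50 nM
- compound 2, `O=c1c(-c2ccc(O)cc2)coc2cc(OCCCCCCO)ccc12`, 120 nM
- compound 3, `C=CCCCCOc1ccc2c(=O)c(-c3ccc(O)cc3)coc2c1`, 150 nM

In an assay (Cricetulus griseus) for inhibition of aldehyde dehydrogenase, mitochondrial (Homo sapiens) (a lower number here means a stronger inhibitor, a higher number a weaker inhibitor), compound 3 gives the highest number of the three. The step of a 3.0-fold higher number from compound 1 to compound 3 (0.48 log units; beyond the scatter) lies beyond the scatter, while the step of a 1.3-fold higher number from compound 2 to compound 3 (0.10 log units; within the scatter) lies within the scatter, so compound 2 and compound 3 cannot be ordered against each other.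

The unmeasured compound 4, `CC(Oc1ccc2c(=O)c(-c3ccc(O)cc3)coc2c1)C(=O)O`, differs from compound 3 in one place: 1-carboxyethyl in place of hex-5-en-1-yl on an oxygen on an aromatic ring. Among the measured compounds shown here, the measured step that bears most on this is the one from compound 1 to compound 3, a 3.0-fold higher number from compound 1 to compound 3 (0.48 log units; beyond the scatter), where loss of the carboxy-bearing chain end raised the number. The step of a 2.4-fold higher number from compound 1 to compound 2 (0.38 log units; beyond the scatter) shows carboxy giving a lower number than hydroxy. Compound 4 brings a carboxy back, but on a far shorter chain, so the size of any gain is uncertain.

Compound 4 is therefore expected to give a lower number than compound 3 in this assay, by about a 1.7-fold lower number from compound 3 to compound 4 (0.22 log units; within the scatter), though the shortened chain makes a smaller gain possible. The estimate for compound 4 is 90 nM, within a range of 30 nM to 300 nM.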

Compound 4, half-maximal inhibitory concentration: 2500 nM
The estimate for compound 4 lay 28-fold (1.44 log units) below the measured number; measured number above the stated range.
By their numbers in this assay, from the lowest: compound 1; then compounds 2 and 3 (each within the scatter of the next); then compound 4.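

In this assay a carboxy group does not by itself keep the number low at this oxygen on an aromatic ring: 1-carboxyethyl in place of 6-carboxyhexyl leaves a carboxy group present, yet the number rises sharply (a 50-fold higher number from compound 1 to compound 4 (1.70 log units; beyond the scatter)). The 1-carboxyethyl group also gives a higher number than both chains without a carboxy group, namely hex-5-en-1-yl (a 17-fold higher number from compound 3 to compound 4 (1.22 log units; beyond the scatter)) and 6-hydroxyhexyl (a 21-fold higher number from compound 2 to compound 4 (1.32 log units; beyond the scatter)). These large steps show that the whole group on this oxygen matters far more than the earlier changes at the chain end suggested, and that the lower number of carboxy over hydroxy, seen with the long chain, does not carry over to compound 4.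

Compound 4 both shortens the chain and places the carboxy group on a branched carbon, so the compounds shown cannot separate these two changes; an unbranched carboxymethyl group or a 3-carboxypropyl chain would bear on that, while an amine at the end of the long chain would test other end groups. No evidence is given that explains the size of this rise.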